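The source may report more compounds than this note shows. Statements on the series, on what has been measured and on what is new or still open speak of the compounds shown alone.

In an ADME assay on Vero cells (Chlorocebus sabaeus) for cytotoxicity, read by resazurin assay, with a stated time of 72 h (a lower number here means that less compound is tolerated, a higher number that more compound is tolerated), the series is small, and compound 1, whose structure is `O=C(/C=C/c1ccc([N+](=O)[O-])o1)c1ccc(I)cc1`, stands at the edge of what the measurement can report. For compound 1 this assay returns only a limit, > 100000 nM, so its true figure is not known. The other measured member, compound 2 with structure `Cc1ccccc1C(=O)/C=C/c1ccc([N+](=O)[O-])o1`, gives in this assay a number of 41300 nM. No single-point step between these two is shown, so the pair only says that one value is a number and the other a limit, as noted in the limit of > 100000 nM in this assay, at which 1 of the 2 values shown sits.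

The next compound, compound 3 with structure `CSc1ccc(C(=O)/C=C/c2ccc([N+](=O)[O-])o2)cc1`, differs from compound 1 in one place: methylsulfanyl in place of iodo on an aromatic carbon. Among the compounds with values here, no measured step informs on this change, and the starting point is itself a limit. The step from compound 1 to compound 3 is therefore expected to be small, an at least 1.1-fold lower number from compound 1 to compound 3 (0.04 log units; that floor lies within the scatter), with no direction claimed beyond the usual scatter. Compound 3 is estimated at 90000 nM in this assay, within a range from 40000 nM to 200000 nM, with a real chance that only a limit is again reported.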

Compound 3, half-maximal cytotoxic concentration: 40700 nM
The estimate for compound 3 lay 2.2-fold (0.34 log units) above the measured number, and the stated range covers the measured number.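

Within the data shown here, this is the first step that can be read at all: in this assay, methylsulfanyl in place of iodo on an aromatic carbon, para to a large group, gives an at least 2.4-fold lower number from compound 1 to compound 3 (0.39 log units; beyond the scatter). The position therefore responds to a change of group, and compound 3 carries a true number where compound 1 carries only a limit. Only a floor for the size of the step is known, and its full size remains unknown, because the value of compound 1 is a limit and not a number: the limit of > 100000 nM in this assay, at which 1 of the 3 values shown sits.

Left open is whether the step belongs to the arrival of methylsulfanyl or to the departure of iodo, and how an amine, a carboxylic acid or a longer chain such as butyl on the same aromatic carbon would read in this assay. Also open, on these data alone, is whether the same exchange would give a step of similar size on another member of the series, since a single pair cannot show a trend.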